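Swapping Thiophen-2-yl for 2-Methoxyphenyl in a Growth Test

This account rests on a few compounds, and the source may have more. Where it says the series, first, only, none or still open, it means among the compounds named here.

Three related compounds have been tested so far. In a functional assay on HCT-116 cells (Homo sapiens) for inhibition, read by sulforhodamine B assay, with a stated time of 48 h, tested at 50 uM (on this read-out lower numbers stand for less inhibition of growth and higher numbers for more inhibition of growth at the one concentration tested), compound 1 `COc1cc(/C=C/C(=O)/C=C/c2ccco2)ccc1OCc1cn(CCCOc2cc(=O)oc3ccccc23)nn1` gives 51%, compound 2 `COc1cc(/C=C/C(=O)/C=C/c2cccs2)ccc1OCc1cn(CCOc2cc(=O)oc3ccccc23)nn1` gives 71% and compound 3 `COc1cc(/C=C/C(=O)/C=C/c2cc(OC)c(OC)c(OC)c2)ccc1OCc1cn(CCCCOc2cc(=O)oc3ccccc23)nn1` gives 63%. Compound 2 and compound 3 lie within the usual scatter of each other, so these two cannot be ranked. Compound 1 lies beyond the scatter under compound 2, which places compound 2 in the upper pair of this small set.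

The next compound, compound 4 `COc1ccccc1/C=C/C(=O)/C=C/c1ccc(OCc2cn(CCOc3cc(=O)oc4ccccc34)nn2)c(OC)c1`, has not yet been measured. It has 2-methoxyphenyl in place of the thiophen-2-yl of compound 2, on a double-bonded chain carbon bound to a double-bonded chain carbon (2-methoxyphenyl in place of thiophen-2-yl on a double-bonded chain carbon bound to a double-bonded chain carbon). Going by the values given here, no two measured compounds differ in only one place, so the data show no direct size for a change like this one. The closest guide is compound 3, which also has a six-membered aromatic ring of carbon only on that chain, although it differs elsewhere too, and gives 63%. A modest fall in this assay is therefore expected, probably close to the edge of the scatter. The expected change is a number 9 percentage points lower from compound 2 to compound 4 (within the scatter). The estimate for compound 4 is 62%, with an expected range from 45% to 78%.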

Compound 4, percent growth inhibition at one concentration: 70%
For compound 4 the middle estimate is 8 percentage points below the measured one; low and high end bracket the measured number.
By their numbers in this assay, from the lowest: compound 1; then compounds 3, 4 and 2 (each within the scatter of the next).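

In this assay, going by these compounds alone, the swap of thiophen-2-yl for 2-methoxyphenyl on a double-bonded chain carbon bound to a double-bonded chain carbon gives a number 1 percentage points lower from compound 2 to compound 4 (within the scatter), the first direct reading of this change in the set. This single pair therefore shows that a five-membered aromatic ring with 1 hetero atom and a six-membered aromatic ring of carbon only, carrying a methoxy group, cannot be told apart at this place, although the entering group has 8 heavy atoms and the leaving group 5. No measurement at hand offers a reason for this match.

Compound 1 and compound 3 differ from compound 2 in more than one place, so the effect of their own groups at this position cannot be separated from the effect of their other differences. On these data alone, it also remains open whether a group of another kind at this place, such as a dimethylamino-substituted phenyl ring or a phenyl ring bearing a carboxylic acid, would likewise leave the number within the scatter of compound 2.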